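The compounds below may be only part of what the source reports. "The series", "measured", "known", "first", "only" and "open" are said of these compounds alone.

Of the compounds shown here, three have been measured in a functional assay on the whole organism (Central nervous system) for activation, with Mus musculus as the target; a lower number here means that less compound is needed, a higher number that more compound is needed for the effect. Compound 1 `COc1ccc(C23CCC(=O)N2CCCO3)cc1` gives only a limit in this assay, < 150 mg/kg, and that limit is one of the values in hand (the limit of < 150 mg/kg in this assay, at which 1 of the 3 values shown sits). Compound 2 `O=C(CCC(=O)c1ccc(Cl)c(Cl)c1)NCCCO` gives 300 mg/kg in this assay. Compound 3 `O=C(CCC(=O)c1cccs1)NCCCO` gives 300 mg/kg in this assay, level with compound 2 at the digits shown, so the two stand within the usual scatter of each other and no order between them can be read.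

Compound 4 `O=C(CCC(=O)c1ccc(Cl)cc1)NCCCO` has not yet been measured. It differs from compound 2 in one place: hydrogen in place of chloro on an aromatic carbon. For the measured compounds named here, no pair of measured compounds differing in one place is available, so there is no measured step to lean on for the size of this change. The expectation is therefore that compound 4 stays close to compound 2, with a step no larger than the scatter of repeated measurements. Compound 4 is expected to give about 300 mg/kg in this assay, with a range from 150 mg/kg to 600 mg/kg. The step expected is no change at the digits printed from compound 2 to compound 4 (within the scatter), which is none beyond the scatter.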

Compound 4, dose for half-maximal effect: 300 mg/kg
Estimate against measurement, compound 4: no gap at the digits printed, within the range that was stated.
By their numbers in this assay, from the lowest: compounds 2, 3 and 4 (each within the scatter of the next). At a limit, below all of these: compound 1.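

In this assay, replacing the chloro group with hydrogen on this aromatic carbon gives no change at the digits printed from compound 2 to compound 4 (within the scatter). For the compounds shown here, this is the first measured step between two compounds that differ in one place, so the size of a change here now rests on a measurement and not on an expectation. For this carbon, ortho to a chloro group, the pair shows that chloro and hydrogen cannot be told apart in this test, although no measurement shown explains why.

This single pair covers only one replacement at one place on the ring. From the compounds shown here alone, whether an amine or a trifluoromethyl group on the same carbon would shift the dose stays open, as does the outcome of replacing the remaining chloro group.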